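The source may report more compounds than this note shows. Statements on the series, on what has been measured and on what is new or still open speak of the compounds shown alone.

Measured so far:
compound 1 `CCCCNC(=O)C1C(C(=O)O)[C@@H]2CC[C@H]1O2`: 10000 nM
compound 2 `CCc1ccccc1NC(=O)C1C(C(=O)O)[C@@H]2CC[C@H]1O2`: 10000 nM
compound 3 `C/C(=N/Nc1ccccc1)c1ccccc1NC(=O)C1C(C(=O)O)[C@@H]2CC[C@H]1O2`: 10000 nM

In an ADME assay on NCI-H460 cells (Homo sapiens) for cytotoxicity, read by MTT assay, with a stated time of 72 h (on this read-out higher numbers stand for weaker inhibition of growth and lower numbers for stronger inhibition of growth), compound 1 gives 10000 nM. Compound 2 gives 10000 nM and compound 3 gives 10000 nM, so compound 1 stands level with both at the digits shown, the nearest being compound 2 and the furthest compound 3, neither differing from it beyond the scatter. Compound 4 `O=C(O)CCCNC(=O)C1C(C(=O)O)[C@@H]2CC[C@H]1O2` differs from compound 1 by carboxy in place of methyl on a saturated chain carbon, three bonds along the chain from an amide-type nitrogen. Going by the values given here, no step between measured compounds is known here. Because compound 1 gives 10000 nM and the very different amide substituents of compounds 2 and 3 leave that figure unchanged, the step of no change at the digits printed from compound 1 to compound 4 (within the scatter) is expected to be none beyond the scatter. Compound 4 is therefore estimated at 10000 nM, with a range from 5000 nM to 20000 nM.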

Compound 4, concentration for 50% growth inhibition: 10000 nM
Compound 4: middle estimate and measured number agree at the digits printed; the range from low to high includes it.
By their numbers in this assay, from the lowest: compounds 1, 2, 3 and 4 (each within the scatter of the next).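

In this assay, going by these compounds alone, the exchange of carboxy for methyl, on a saturated chain carbon, three bonds along the chain from an amide-type nitrogen, gives no change at the digits printed from compound 1 to compound 4 (within the scatter) and is the first change here that can be read in one place. At this position, then, the added carboxy leaves the printed figure as it stood for the methyl end of the butyl chain. Nothing measured here offers a reason for this result. From the compounds shown here alone, whether an amine, a methyl ester or a longer chain at this carbon would read differently stays open.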